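The source may report more compounds than this note shows. Statements on the series, on what has been measured and on what is new or still open speak of the compounds shown alone.

Compound 1 `CC(=O)c1ccc(NC(=O)Nc2cc(C)nc3ccccc23)cc1` was examined in an ADME assay on BJ cells (Homo sapiens) for cytotoxicity, with a stated time of 72 h (a lower number here means that less compound is needed, a higher number that more compound is needed for the effect), where compound 1 gives 22000 nM. Compound 2 `Cc1cc(NC(=O)Nc2ccccc2C(C)(C)C)c2ccccc2n1`, which shares the same core, gives 22000 nM in this assay, and the two values are level with each other, within the usual scatter of repeated measurements, so no difference between compound 1 and compound 2 can be read from them. Compound 3 `Cc1cc(NC(=O)Nc2ccc(C(F)(F)F)cc2)c2ccccc2n1` has not yet been measured in this assay. It differs from compound 1 in a single place: trifluoromethyl in place of acetyl on an aromatic carbon. Going by the values given here, no measured step of this kind exists among the compounds so far, and compounds 1 and 2 sit at the same level despite carrying different groups, so the change from compound 1 to compound 3 is expected to produce a step of no change at the digits printed from compound 1 to compound 3 (within the scatter), nothing beyond the scatter. Compound 3 is therefore estimated to give about 22000 nM in this assay, with a likely range from 8000 nM to 60000 nM.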

Compound 3, half-maximal effective concentration: > 25000 nM
Compound 3 gave a limit, no number (the forecaster's own chance of this, stated with the estimate: 20%); middle value at least 1.1-fold (0.05 log units) away from the limit.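

In this assay compound 3 gives > 25000 nM, which is a limit of the assay and not a number. From the compounds shown here alone, replacing acetyl with trifluoromethyl on this aromatic carbon, para to a large group, gives an at least 1.1-fold higher number from compound 1 to compound 3 (0.05 log units; that floor lies within the scatter), so the true size of the step remains unknown. The new information is that the number does not come down when the hydrogen-bond acceptor counted in acetyl is lost at this position, though this reading rests on a single limit: the limit of > 25000 nM in this assay, at which 1 of the 3 values shown sits.

Going by these compounds, how far compound 3 really lies from compound 1 remains open, since only a floor for the step can be read. On these data alone, it is also open whether an amine, a carboxylic acid or a longer chain at this position would leave the number as high or bring it down.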